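Notes on the step from compound 3 to compound 4

This account rests on a few compounds, and the source may have more. Where it says the series, first, only, none or still open, it means among the compounds named here.

Of the compounds shown here, three have numbers so far in a functional assay on the whole organism with Mus musculus as the target; on this read-out lower numbers stand for an effect already at smaller amounts and higher numbers for an effect only at larger amounts of compound. Compound 1 `O=C1CCC(Cc2ccc(Br)cc2)C(=O)N1` gives 56.3 mg/kg. Compound 2 `CN1C(=O)CCC(Cc2ccccc2Br)C1=O` gives 256 mg/kg. Compound 3 `CN1C(=O)CCC(Cc2ccc(Cl)cc2Cl)C1=O` gives 153 mg/kg, the second highest of the three numbers; its nearest neighbour is compound 2, whose number lies within the scatter of that of compound 3, while compound 1 lies beyond the scatter with the lower number. Within the data shown here, compound 1 and compound 2 each differ from compound 3 in more than one place, so no single step between measured compounds is available as a guide.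

Compound 4 `CN1C(=O)CCC(Cc2ccc(Cl)cc2)C1=O` is one change away from compound 3: hydrogen in place of chloro on an aromatic carbon. The shared core is otherwise kept. Among the measured compounds shown here, the change has no measured counterpart, so the expectation rests on the spread of the three numbers alone. The step of a 1.5-fold lower number from compound 3 to compound 4 (0.18 log units; within the scatter) is expected to be small, towards a lower number, near the edge of the scatter. Compound 4 is accordingly estimated at 100 mg/kg, with a range from 50 mg/kg to 250 mg/kg.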

Compound 4, dose for half-maximal effect: 124 mg/kg
Compound 4: middle estimate off by 1.2-fold (0.09 log units), on the low side; measured number inside the range.
By their numbers in this assay, from the lowest: compound 1; then compounds 4, 3 and 2 (each within the scatter of the next, the first and the last beyond it).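

Hydrogen in place of chloro on the aromatic carbon ortho to a large group gives a 1.2-fold lower number from compound 3 to compound 4 (0.09 log units; within the scatter) in this assay, the first step in the series that can be read at a single place. At this position, with the other chloro group kept, the read-out therefore does not separate chloro from hydrogen beyond the scatter. No measurement at hand gives a reason for this result.

Still open, going by these compounds, is whether a different group on this aromatic carbon, such as methoxy, an amine or a carboxylic acid, would also stay within the scatter of compound 3. The compounds shown also offer no single-place step for the methyl group on the nitrogen of the shared core, or for bromo against chloro at the other aromatic position.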